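The source may report more compounds than this note shows. Statements on the series, on what has been measured and on what is new or still open speak of the compounds shown alone.

The measured compounds, with their values in a functional assay on BE(2)-C cells (Homo sapiens) for inhibition, read by MTT assay, with a stated time of 72 h; on this read-out lower numbers stand for stronger inhibition of growth and higher numbers for weaker inhibition of growth:
compound 1 `N#C/C(=C\c1ccc([N+](=O)[O-])cc1)C(=O)c1c[nH]c2ccccc12` gives 40000 nM
compound 2 `N#C/C(=C\c1ccc[nH]1)C(=O)NCc1ccc(Cl)c(Cl)c1` gives 43000 nM
compound 3 `COc1ccc(CNC(=O)/C(C#N)=C/c2cccc3ccccc23)cc1` gives 14000 nM

Of the three, compound 3 stands lowest in this assay; its nearest neighbour is compound 1 and its furthest is compound 2, both gaps lying beyond the scatter. Compound 4 `N#C/C(=C\c1cccc2ccccc12)C(=O)NCc1ccc(Cl)c(Cl)c1` differs from compound 3 in one place: 3,4-dichlorophenyl in place of 4-methoxyphenyl on a saturated chain carbon bound to an amide-type nitrogen. Going by the values given here, no measured pair isolates this change, so its size is not known from the data; compound 2 carries the same 3,4-dichlorophenyl on a saturated chain carbon bound to an amide-type nitrogen and gives a high number, but its other part differs too. The step of a 1.3-fold higher number from compound 3 to compound 4 (0.11 log units; within the scatter) is therefore expected to be small, a modest rise at most, within or near the scatter. Compound 4 is estimated at 18000 nM, with a range from 7000 nM to 45000 nM.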

Compound 4, concentration for 50% growth inhibition: 7000 nM
Compound 4: the middle estimate sits 2.6-fold (0.41 log units) above what was measured; measured number inside the range.
By their numbers in this assay, from the lowest: compounds 4 and 3 (each within the scatter of the next); then compounds 1 and 2 (each within the scatter of the next).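

In this assay, going by these compounds alone, this pair isolates the change on a saturated chain carbon bound to an amide-type nitrogen for the first time, something the earlier compounds could not do. It gives a 2.0-fold lower number from compound 3 to compound 4 (0.30 log units; within the scatter) and so does not separate 3,4-dichlorophenyl from 4-methoxyphenyl at this place. Nothing at hand bears on why the two groups read alike.

Going by these compounds, whether a carboxylic acid or a primary amine on that phenyl ring would read differently stays open. So does whether the same exchange would read alike on a core other than that of compound 3.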